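The compounds below may be only part of what the source reports. "The series", "measured", "known", "first", "only" and "open" are said of these compounds alone.

Compound 1 `COc1ccc2c(=O)c(/C=C/C(=O)NCc3ccccc3)coc2c1`: 11800 nM
Compound 2 `COc1ccc2c(=O)c(/C=C/C(=O)Nc3ccccc3Cl)coc2c1`: 29900 nM
Compound 3 `COc1cccc(NC(=O)/C=C/c2coc3cc(OC)ccc3c2=O)c1`: 12800 nM

All three were tested in a functional assay on A549 cells (Homo sapiens) for inhibition, read by MTT assay, with a stated time of 48 h; a higher number here means a weaker inhibitor, a lower number a stronger inhibitor. Compound 3 stands second highest of the three: compound 1 lies within the scatter of it, a 1.1-fold higher number from compound 1 to compound 3 (0.04 log units; within the scatter), while compound 2 gives a clearly higher number. Compound 4 `COc1ccc2c(=O)c(/C=C/C(=O)Nc3ccccc3OC)coc2c1` has not yet been measured; it differs from compound 3 by 2-methoxyphenyl in place of 3-methoxyphenyl on an amide-type nitrogen. The step that bears most on this change is a 2.3-fold lower number from compound 2 to compound 3 (0.37 log units; beyond the scatter), in which the group on the amide-type nitrogen also changed and which was modest; the related step of a 2.5-fold higher number from compound 1 to compound 2 (0.40 log units; beyond the scatter) was modest too. A modest shift toward a higher number is therefore expected for compound 4, a 1.4-fold higher number from compound 3 to compound 4 (0.15 log units; within the scatter). Compound 4 is estimated at 18000 nM, within 8000 nM to 45000 nM.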

Compound 4, half-maximal inhibitory concentration: > 100000 nM
Compound 4: no number, only a limit; the forecaster's own chance of this, stated with the estimate: 10%; middle value at least 5.5-fold (0.74 log units) away from the limit.
By their numbers in this assay, from the lowest: compounds 1 and 3 (each within the scatter of the next); then compound 2. At a limit, above all of these: compound 4.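

Compound 4 gives only a limit of the assay, not a number: the limit of > 100000 nM in this assay, at which 1 of the 4 values shown sits. The 3-methoxyphenyl and 2-methoxyphenyl groups have the same atoms, yet exchanging them on the amide-type nitrogen gives an at least 7.8-fold higher number from compound 3 to compound 4 (0.89 log units; beyond the scatter), so this place is sensitive to how the methoxy group is attached, not only to which atoms are present. The 2-methoxyphenyl group also separates compound 4 from the other two compounds, with an at least 3.3-fold higher number from compound 2 to compound 4 (0.52 log units; beyond the scatter) and an at least 8.4-fold higher number from compound 1 to compound 4 (0.92 log units; beyond the scatter).

On these data alone, how far beyond the limit compound 4 lies stays open. So does whether an amine or a carboxylic acid in place of the methoxy on the 2-methoxyphenyl group would give the same result.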